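The compounds below may be only part of what the source reports. "The series", "measured", "known", "first", "only" and "open" are said of these compounds alone.

In an ADME assay on microsomes from liver (Rattus norvegicus) for metabolic stability, read by LC-MS, using NADPH, with a stated time of 30 min, tested at 0.1 uM (a lower number here means that less of the compound is left, a higher number that more of the compound is left), compound 1 (`CS(=O)(=O)Nc1ccc2nccc(-c3ccncc3)c2n1`) gives 94% and compound 2 (`CS(=O)(=O)Nc1cccc(-c2ccc3nccc(-c4ccncc4)c3n2)c1`) stands lower with 49% of the compound left, a gap well beyond the usual scatter. Compound 2 is therefore the lower of the two measured compounds, though two numbers are too few to show a trend.

Compound 3 (`Nc1cccc(-c2ccc3nccc(-c4ccncc4)c3n2)c1`) has not been measured yet. It differs from compound 2 in one place: hydrogen in place of methylsulfonyl on a nitrogen on an aromatic ring. Put simply, hydrogen takes the place of methylsulfonyl on a nitrogen on an aromatic ring, which turns methanesulfonamido into amino.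

Going by the values given here, no measured pair of compounds shows this change, so the data give no direct guide to its size. Compound 2 at 49% leaves room for movement either way. A modest drop is expected, possibly no larger than the scatter, and the uncertainty is wide. The estimated change is a number 9 percentage points lower from compound 2 to compound 3 (within the scatter) on this reasoning. For compound 3 the estimated value is 40% with an expected range from 15% to 70% in this measurement.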

Compound 3, percent of the compound remaining: 61%
For compound 3 the middle estimate is 21 percentage points below the measured one, within the range that was stated.
By their numbers in this assay, from the lowest: compound 2; then compound 3; then compound 1.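

In this assay, taking methylsulfonyl off the nitrogen on the aromatic ring, which turns methanesulfonamido into amino, gives a number 12 percentage points higher from compound 2 to compound 3 (beyond the scatter). Going by these compounds alone, this is the first one-place reading of this change, and it shows that the methanesulfonamido group is not required for more of the compound to be left: the simple amino group does better here. Replacing methanesulfonamido on an aromatic carbon with 3-aminophenyl gives a number 33 percentage points lower from compound 1 to compound 3 (beyond the scatter), so even with its amino group, compound 3 stays well short of compound 1, and nothing shown explains either step.

Going by these compounds, it remains open whether the gain is specific to removing methylsulfonyl or would also appear with another group on that nitrogen, such as acetyl or methyl. On these data alone, it is also open how much of the shortfall from compound 1 belongs to the phenyl ring itself and how much to its amino group, which an unsubstituted phenyl or a phenyl carrying a carboxylic acid could help separate.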